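A few compounds are considered here, and "the series" means these few. Any claim that something is new, unique, unknown or untested is made for them only; others in the source may bear on it.

Measured so far:
compound 1, `C[C@H]1CC[C@@H]2[C@@H](OC(=O)[C@]23CC(c2ccccc2F)=NO3)[C@]2(C)C(=O)C=C[C@@]12O`, in a physicochemical assay for lipophilicity (a higher number here means a more lipophilic compound, a lower number a more polar compound), gives 1.58
compound 2, `C[C@H]1CC[C@@H]2[C@@H](OC(=O)[C@]23CC(c2ccc(Br)cc2)N(c2ccccc2)O3)[C@]2(C)C(=O)C=C[C@@]12O`, in this assay gives 4

Compound 2 stands highest of the two numbers; its nearest neighbour is compound 1, which lies lower by a gap beyond the usual scatter. Compound 3, `COc1ccc(C2C[C@@]3(ON2c2ccccc2)C(=O)O[C@@H]2[C@H]3CC[C@H](C)[C@]3(O)C=CC(=O)[C@@]23C)cc1Br`, has not yet been measured in this assay. It differs from compound 2 in one place: 3-bromo-4-methoxyphenyl in place of 4-bromophenyl on a saturated ring carbon. For the measured compounds named here, no measured pair isolates such a change, so the expectation rests on compound 2 alone. The expected step, a number 0.10 log units lower from compound 2 to compound 3 (within the scatter), is small, without a shift beyond the scatter in either direction. Compound 3 is therefore estimated at 3.9, within a range from 3.5 to 4.4.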

Compound 3, partition coefficient: 3.98
For compound 3 the middle estimate is 0.08 log units below the measured one; the range from low to high includes it.
By their numbers in this assay, from the lowest: compound 1; then compounds 3 and 2 (each within the scatter of the next).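

In this assay, putting 3-bromo-4-methoxyphenyl in place of 4-bromophenyl on the saturated ring carbon amounts to a number 0.02 log units lower from compound 2 to compound 3 (within the scatter). For the compounds shown here, the first measured change at this position thus leaves compound 2 and compound 3 indistinguishable, although the entering group is larger and carries a hydrogen-bond acceptor. No measurement at hand accounts for this result. This single pair cannot separate the methoxy group from the different bromine placement. It also leaves open whether an amine or a carboxylic acid on this aromatic ring would give a step beyond the scatter.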